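The compounds below may be only part of what the source reports. "The series", "measured", "known", "first", "only" and "open" are said of these compounds alone.

In a functional assay on HT-29 cells (Homo sapiens) for antiproliferative activity, read by sulforhodamine B assay, with a stated time of 72 h (a higher number here means a weaker inhibitor, a lower number a stronger inhibitor), compound 1 (`NC(=S)N/N=C/c1ccc2cccnc2n1`) gives 12800 nM and compound 2 (`S=C(N/N=C/c1ccc2ccccc2n1)Nc1cccc(Br)c1`) gives 58900 nM. Compound 2 therefore holds the higher of the two numbers, and the gap between them lies beyond the usual scatter. The two compounds differ in more than one place, however, so this gap cannot be tied to any single change. Compound 3 (`S=C(N/N=C/c1ccc2ccccc2n1)Nc1ccc(Br)cc1`) departs from compound 2 in one place only, with 4-bromophenyl in place of 3-bromophenyl on an amide-type nitrogen. Among the measured compounds shown here, the two have the same atoms, joined differently, and no measured pair shows what such a swap does. No shift beyond the scatter is therefore expected in this assay. The expected change is a 1.3-fold lower number from compound 2 to compound 3 (0.12 log units; within the scatter). For compound 3 the estimated value is 45000 nM, with an expected range of 15000 nM to 100000 nM.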

Compound 3, half-maximal inhibitory concentration: 54400 nM
The estimate for compound 3 lay 1.2-fold (0.08 log units) below the measured number, and the stated range covers the measured number.
By their numbers in this assay, from the lowest: compound 1; then compounds 3 and 2 (each within the scatter of the next).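

In this assay, among the compounds shown here, the change of 3-bromophenyl to 4-bromophenyl on the amide-type nitrogen gives a 1.1-fold lower number from compound 2 to compound 3 (0.03 log units; within the scatter), the first step that can be tied to a single change. For this pair, exchanging one of these two bromophenyl groups for the other leaves the numbers within the scatter, so the measurements separate neither group from the other. No measurement offered here explains this result.

On these data alone, the two compounds speak only to these two bromophenyl groups, so the effect of a phenyl without bromine, a 4-methoxyphenyl or a short alkyl chain on that nitrogen remains open. As far as these compounds go, it is also open whether the same exchange would give a similar step on the core of compound 1.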